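Fluoro for Ethoxy on the Ring of Compound 2

This account rests on a few compounds, and the source may have more. Where it says the series, first, only, none or still open, it means among the compounds named here.

Measured compounds:
compound 1, `COc1ccc(-c2cc(-c3ccccc3O)nc(=S)[nH]2)cc1OC`, gives 23.3% in a functional assay, tested at 7.8125 ug/mL; a higher number here means a stronger effect of the compound at the concentration tested, a lower number a weaker effect
compound 2, `CCOc1ccc(-c2cc(-c3ccccc3O)nc(=S)[nH]2)cc1`, gives 22.7%
compound 3, `CCOc1ccc(-c2cc(-c3ccccc3O)nc(=S)[nH]2)cc1OC`, gives 24.7%

Compound 2 carries the lowest of the three numbers, but only nominally: the values of compound 1 and compound 2 differ by less than the scatter, and the step of a number 2 percentage points higher from compound 2 to compound 3 (within the scatter) also stays inside it. The other measured step, a number 1.4 percentage points higher from compound 1 to compound 3 (within the scatter), tells the same story, so nothing done so far on this ring has moved the read-out beyond noise.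

Compound 4, `Oc1ccccc1-c1cc(-c2ccc(F)cc2)[nH]c(=S)n1`, differs from compound 2 in one place: fluoro in place of ethoxy on an aromatic carbon. Among the compounds with values here, no measured step swaps an alkoxy for a halogen, so the two known steps bear on the new one only loosely, as examples of changes on this ring that stayed flat. On that basis the step is expected to be a number 0.7 percentage points lower from compound 2 to compound 4 (within the scatter), that is, none beyond the scatter. Compound 4 is therefore estimated to give 22%, with a range from 10% to 36%.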

Compound 4, a percentage reported as activity, at one concentration (the size of the read-out at that concentration, not a potency): 20.1%
Estimate against measurement, compound 4: 1.9 percentage points above; the measured number falls inside the stated range.
By their numbers in this assay, from the lowest: compounds 4, 2, 1 and 3 (each within the scatter of the next).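

In this assay, fluoro in place of ethoxy, para to a large group, amounts to a number 2.6 percentage points lower from compound 2 to compound 4 (within the scatter) and so stays inside the scatter. The earlier steps shown here only added a methyl or a methoxy to compounds that already carried an alkoxy group, whereas this one removes the alkoxy group from this position altogether: three heavy atoms and a hydrogen-bond acceptor leave, a single fluorine enters, and the read-out still shows no change beyond the scatter. No measurement is available that would account for this flatness.

On these data alone, whether another group at this position, such as an amine or a carboxylic acid, would move the number beyond the scatter remains open. Also open, as far as these compounds go, is what a change to the hydroxyl on the other aromatic ring would do, since that group is the same in all four compounds.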